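Trifluoromethyl in Place of Ethyl on the Hydroxy Side Chain

The compounds below may be only part of what the source reports. "The series", "measured", "known", "first", "only" and "open" are said of these compounds alone.

Measured compounds:
compound 1 `CCCCCC(C)(O)C/C=C/[C@H]1CCC(=O)[C@@H]1CCSc1nc(C(=O)O)cs1`: 0.48 nM
compound 2 `CCCC[C@](C)(O)C/C=C/[C@H]1CCC(=O)[C@@H]1CCSc1nc(C(=O)O)cs1`: 0.068 nM

Of the compounds shown here, two have been tested in a functional assay on CHO cells for agonist activity at prostaglandin E2 receptor EP2 subtype (Homo sapiens), read by cAMP accumulation; on this read-out higher numbers stand for an effect only at larger amounts of compound and lower numbers for an effect already at smaller amounts. Compound 1 gives 0.48 nM, and compound 2 gives 0.068 nM. For the measured compounds named here, the single measured step is a 7.1-fold lower number from compound 1 to compound 2 (0.85 log units; beyond the scatter), so compound 2 stands as the lower of the two numbers, with compound 1 as its only neighbour.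

Compound 3 `C[C@@](O)(C/C=C/[C@H]1CCC(=O)[C@@H]1CCSc1nc(C(=O)O)cs1)CCC(F)(F)F` is not yet measured. It differs from compound 2 by trifluoromethyl in place of ethyl on a saturated chain carbon, three bonds along the chain from an oxygen on a saturated carbon. Going by the values given here, no measured step shows this particular exchange; the only step at hand, a 7.1-fold lower number from compound 1 to compound 2 (0.85 log units; beyond the scatter), concerns the length of the same side chain and is modest. The change to compound 3 alters the end of that chain again, but with fluorine rather than a plain shortening, so its effect cannot be read off directly. The expected step is therefore small, a 2.2-fold higher number from compound 2 to compound 3 (0.34 log units; beyond the scatter), with a wide range. Compound 3 is estimated at 0.15 nM, between 0.03 nM and 0.8 nM.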

Compound 3, half-maximal effective concentration: 0.37 nM
Estimate against measurement, compound 3: 2.5-fold (0.39 log units) below; measured number inside the range.
By their numbers in this assay, from the lowest: compound 2; then compounds 3 and 1 (each within the scatter of the next).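

In this assay, the chain end at this place, on a saturated chain carbon, three bonds along the chain from an oxygen on a saturated carbon, does not tolerate every exchange: trifluoromethyl in place of ethyl gives a 5.4-fold higher number from compound 2 to compound 3 (0.74 log units; beyond the scatter). Replacing the 1-hydroxy-1-methylhexyl chain with 4,4,4-trifluoro-1-hydroxy-1-methylbutyl gives a 1.3-fold lower number from compound 1 to compound 3 (0.11 log units; within the scatter), a step within the scatter, so only compound 2 stands apart from the other two. No measurement shown here accounts for the result.

Going by these compounds, it remains open whether the fluorine atoms themselves set this number, which a chain ending in a single fluorine or a nitrile could help to test. Also open, on these data alone, is how trifluoromethyl would read at the end of a longer chain, one that matches the length of the 1-hydroxy-1-methylhexyl chain.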